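Sulfonamide nitrogen substituent change on the shared core

The source may report more compounds than this note shows. Statements on the series, on what has been measured and on what is new or still open speak of the compounds shown alone.

Measured so far:
compound 1 `CC[C@@H]1C(=O)N(C)c2cnc(Nc3ccc(S(=O)(=O)NC4CCCC4)cc3)nc2N1C1CCCC1` 1710 nM
compound 2 `CCC1C(=O)N(C)c2cnc(Nc3ccc(S(=O)(=O)NC)cc3)nc2N1c1ccn(C)n1` 18800 nM
compound 3 `CCCNC(=O)c1ccc2c(ccn2-c2ncc3c(n2)N(C2CCCC2)[C@H](CC)C(=O)N3C)c1` 786 nM

In a functional assay on NCI-H1975 cells (Homo sapiens) for antiproliferative activity, read by CCK-8 assay, with a stated time of 72 h (a lower number here means a stronger inhibitor of growth, a higher number a weaker inhibitor of growth), compound 1 sits second highest of the three numbers; compound 3 gives a lower number and compound 2 a much higher one, both gaps beyond the scatter, though neither pair is a single-change step.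

Compound 4 `CC[C@@H]1C(=O)N(C)c2cnc(Nc3ccc(S(=O)(=O)NCCCO)cc3)nc2N1C1CCCC1` differs from compound 1 in one place: 3-hydroxypropyl in place of cyclopentyl on a sulfonamide nitrogen. Within the data shown here, no measured pair shows this change alone, so its size is unknown. A small shift toward a higher number, likely within the scatter, is expected, a 1.5-fold higher number from compound 1 to compound 4 (0.16 log units; within the scatter). Compound 4 is therefore estimated at 2500 nM, with a range of 900 nM to 7000 nM.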

Compound 4, concentration for 50% growth inhibition: 2140 nM
Beside the measured number, compound 4's estimate is 1.2-fold (0.07 log units) above it, and the stated range covers the measured number.
By their numbers in this assay, from the lowest: compound 3; then compounds 1 and 4 (each within the scatter of the next); then compound 2.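

In this assay, a step of a 1.3-fold higher number from compound 1 to compound 4 (0.10 log units; within the scatter) comes with 3-hydroxypropyl in place of cyclopentyl on a sulfonamide nitrogen. Among these compounds, this is the first single-change reading at this position: on the shared core, the ring and the open chain read alike, so the ring is not required for this level of growth inhibition. No evidence on the cause is at hand.

As far as these compounds go, whether an amine or a carboxylic acid at the end of the chain, or a longer chain, would read alike stays open. This single pair also leaves open whether the result holds on other cores.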